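Hydroxymethyl in place of ethoxycarbonyl on the cyclopropane core

The source may report more compounds than this note shows. Statements on the series, on what has been measured and on what is new or still open speak of the compounds shown alone.

Three stereoisomers share one core. Compound 1 `CCOC(=O)[C@]1(C(=O)Nc2ccccc2Cl)C[C@@H]1c1cc(OC)c(OC)c(OC)c1` sits at the limit of a functional assay on HeLa cells (Homo sapiens) for cytotoxicity, read by MTT assay, with a stated time of 48 h (a lower number here means a stronger inhibitor, a higher number a weaker inhibitor), giving > 100000 nM, which is a limit rather than a number. Compound 2 `CCOC(=O)[C@@]1(C(=O)Nc2ccccc2Cl)C[C@H]1c1cc(OC)c(OC)c(OC)c1` gives 14400 nM and compound 3 `CCOC(=O)[C@]1(C(=O)Nc2ccccc2Cl)C[C@H]1c1cc(OC)c(OC)c(OC)c1` gives 42400 nM; their steps are an at least 6.9-fold lower number from compound 1 to compound 2 (0.84 log units; beyond the scatter), an at least 2.3-fold lower number from compound 1 to compound 3 (0.37 log units; beyond the scatter) and a 2.9-fold higher number from compound 2 to compound 3 (0.47 log units; beyond the scatter). Compound 2 thus holds the lowest of the two numbers shown. Compound 4 `COc1cc([C@@H]2C[C@@]2(CO)C(=O)Nc2ccccc2Cl)cc(OC)c1OC` differs from compound 2 by hydroxymethyl in place of ethoxycarbonyl on a saturated ring carbon. Among the compounds with values here, none of the measured steps concern such a change. Each measured pair differs only in configuration, as shown by the fact that compounds 1 and 2 differ only in the configuration as drawn, the fact that compounds 1 and 3 differ only in the configuration as drawn and (the fact that compounds 2 and 3 differ only in the configuration as drawn). Within the data shown here, no measured step bears directly on this one. Compound 4 is therefore estimated near 30000 nM, between 8000 nM and 150000 nM, an expected step of a 2.1-fold higher number from compound 2 to compound 4 (0.32 log units; beyond the scatter).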

Compound 4, half-maximal inhibitory concentration: 13300 nM
Beside the measured number, compound 4's estimate is 2.3-fold (0.35 log units) above it; measured number inside the range.
By their numbers in this assay, from the lowest: compounds 4 and 2 (each within the scatter of the next); then compound 3. At a limit, above all of these: compound 1.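

In this assay, hydroxymethyl in place of ethoxycarbonyl on a saturated ring carbon gives a 1.1-fold lower number from compound 2 to compound 4 (0.03 log units; within the scatter), the first step shown that alters a group at this position rather than configuration. In the configuration of compound 2, then, ethoxycarbonyl can give way to a group with fewer heavy atoms and a hydrogen-bond donor, with the step staying within the scatter. Nothing at hand accounts for this result. The compounds shown leave open whether hydroxymethyl behaves alike in the configurations of compound 1 and compound 3. They also leave open what a carboxylic acid or an amine would give on this carbon.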